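This account rests on a few compounds, and the source may have more. Where it says the series, first, only, none or still open, it means among the compounds named here.

Compound 1 `NC(=S)N/N=C/c1ccc2ccccc2n1` carries a free amide-type nitrogen, and in a functional assay on HeLa cells (Homo sapiens) for antiproliferative activity, read by sulforhodamine B assay, with a stated time of 72 h (on this read-out higher numbers stand for weaker inhibition and lower numbers for stronger inhibition), compound 1 gives 960 nM. Compound 2 `S=C(N/N=C/c1ccc2ccccc2n1)Nc1ccc(Br)cc1` adds a 4-bromophenyl there; in this assay compound 2 gives 56800 nM, the highest of the two numbers shown, with a 59-fold higher number from compound 1 to compound 2 (1.77 log units; beyond the scatter). Compound 3 `Fc1ccccc1NC(=S)N/N=C/c1ccc2ccccc2n1` bears a 2-fluorophenyl instead, and in this assay compound 3 returns only a limit, > 100000 nM. That reading sits at the limit of > 100000 nM in this assay, at which 1 of the 3 values shown sits. The step to it is an at least 100-fold higher number from compound 1 to compound 3 (2.01 log units; beyond the scatter), while between the two aryl compounds there is an at least 1.7-fold higher number from compound 2 to compound 3 (0.24 log units; that floor lies within the scatter).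

Compound 4 `FC(F)(F)c1ccc(NC(=S)N/N=C/c2ccc3ccccc3n2)cc1` differs from compound 2 by trifluoromethyl in place of bromo on an aromatic carbon. Among the compounds with values here, the only measured step touching the aryl group, from compound 2 to compound 3, stays within the scatter, so a swap of one para substituent for another is expected to move this assay little. Compound 4 is therefore expected at a 1.1-fold higher number from compound 2 to compound 4 (0.02 log units; within the scatter), an estimate of 60000 nM with a range of 20000 nM to 150000 nM.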

Compound 4, half-maximal inhibitory concentration: 59100 nM
The estimate for compound 4 lay 1.0-fold (0.01 log units) above the measured number, and the stated range covers the measured number.
By their numbers in this assay, from the lowest: compound 1; then compounds 2 and 4 (each within the scatter of the next). At a limit, above all of these: compound 3.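

In this assay, the step of a 1.0-fold higher number from compound 2 to compound 4 (0.02 log units; within the scatter) is the only one shown between two aryl compounds with a number at both ends, whereas the earlier comparison of aryl compounds rested on a limit. It shows that, on an aromatic carbon para to a large group, trifluoromethyl with its four heavy atoms can take the place of bromo with its one and leave the read-out within the scatter. Nothing given here explains why this exchange leaves the number where it is.

Going by these compounds, what remains open is whether an amine or a carboxylic acid on that same carbon would also leave the number unchanged. On these data alone, it is also open whether a methyl or a longer alkyl chain on the amide-type nitrogen would stay near compound 1, at 960 nM, or move as far as the aryl groups do.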